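The source may report more compounds than this note shows. Statements on the series, on what has been measured and on what is new or still open speak of the compounds shown alone.

Measured compounds:
Compound 1 `O=C(Nc1ccc(-n2ccc3c(NC(=O)c4ccccc4)ncnc32)cc1)Nc1cccc(C(F)(F)F)c1`: in an ADME assay on HS27 cells (Homo sapiens) for antiproliferative activity, read by MTT assay, with a stated time of 24 h (on this read-out lower numbers stand for stronger inhibition and higher numbers for weaker inhibition), compound 1 gives 4500 nM.
Compound 2 `Cc1cn(-c2cc(C(=O)Nc3ccc(-n4ccc5c(NC(=O)c6ccccc6)ncnc54)cc3)cc(C(F)(F)F)c2)cn1`: in this assay compound 2 gives 2800 nM.
Compound 3 `Nc1ncnc2c1ccn2-c1ccc(NC(=O)Nc2cc(C(F)(F)F)cc(C(F)(F)F)c2)cc1`: in this assay compound 3 gives 9500 nM.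

Compound 2 carries the lowest number of the three. Its gap to compound 1 lies within the scatter, so these two cannot be placed in order; its gap to compound 3 lies beyond the scatter. Compound 4 `O=C(Nc1ccc(-n2ccc3c(NC(=O)c4ccccc4)ncnc32)cc1)c1cccc(C(F)(F)F)c1` has not yet been measured in this assay. It differs from compound 2 in one place: hydrogen in place of 4-methyl-1H-imidazol-1-yl on an aromatic carbon. Among the compounds with values here, no pair of measured compounds differing in only one place is available, so the size of this particular change has no direct precedent in the set. What is retained from compound 2 in compound 4 is also largely present in compound 1, which gives 4500 nM and sits within the scatter of compound 2. On that basis the step of a 1.4-fold higher number from compound 2 to compound 4 (0.15 log units; within the scatter) is expected to be small, if anything toward a slightly higher number, and not beyond the scatter. Compound 4 is therefore estimated to give about 4000 nM, with a range from 1500 nM to 11000 nM.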

Compound 4, half-maximal inhibitory concentration: 5900 nM
The estimate for compound 4 lay 1.5-fold (0.17 log units) below the measured number; the measured number falls inside the stated range.
By their numbers in this assay, from the lowest: compounds 2, 1, 4 and 3 (each within the scatter of the next, the first and the last beyond it).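

In this assay, within the data shown here, hydrogen in place of 4-methyl-1H-imidazol-1-yl on an aromatic carbon gives a 2.1-fold higher number from compound 2 to compound 4 (0.32 log units; beyond the scatter) and this is the first step in the set that isolates a single place, showing that what this carbon carries can shift the number beyond the scatter, if only modestly. The position, meta to a trifluoromethyl group on a six-membered aromatic ring of carbon only, therefore responds to this change, although one step cannot show how far that response extends. By contrast, 3-(trifluoromethyl)phenyl in place of (3-(trifluoromethyl)phenyl)amino on a carbonyl carbon gives a 1.3-fold higher number from compound 1 to compound 4 (0.12 log units; within the scatter) and that step lies within the scatter, so it cannot be read as a change, and nothing available explains either step.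

The compounds shown leave open whether the first step belongs to the whole 4-methyl-1H-imidazol-1-yl group or only to part of it, which a plain imidazole without the methyl, or an amine or a methoxy group on the same carbon, would help to separate. They also leave open whether the same exchange would give a step of similar size with (3-(trifluoromethyl)phenyl)amino on the carbonyl carbon.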